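Nitro in Place of Hydrogen on the Phenyl Group

A few compounds are considered here, and "the series" means these few. Any claim that something is new, unique, unknown or untested is made for them only; others in the source may bear on it.

Within the data shown here, compound 1 `O=C(c1ccccc1)c1sc(N(c2ccccc2)c2ccccc2)nc1-c1ccccc1` stands highest of the two compounds measured so far in an assay for inhibition of Polyunsaturated fatty acid 5-lipoxygenase (Homo sapiens), read by spectrophotometry, tested at 10 uM (a lower number here means less inhibition, a higher number more inhibition at the concentration tested (going by the name of the read-out)), where compound 1 gives 48.6%. The nearest neighbour, compound 2 `COc1ccc(-c2nc(N(C)Cc3ccccc3)sc2C(=O)c2ccccc2)cc1`, gives 17.7% in this assay, a gap beyond the usual scatter; the two differ in more than one place, so the values only show where each stands. Compound 3 `O=C(c1ccccc1)c1sc(N(c2ccccc2)c2ccccc2)nc1-c1ccc([N+](=O)[O-])cc1` has not yet been measured. It differs from compound 1 by nitro in place of hydrogen on an aromatic carbon, placed on an aromatic carbon of a six-membered aromatic ring of carbon only, para to a large group. Among the measured compounds shown here, no step between two measured compounds that differ in one place is available to guide the change, so the size of the step from compound 1 to compound 3 is estimated rather than derived; the author expects a number 1.4 percentage points higher from compound 1 to compound 3 (within the scatter), a step that may well lie within the scatter. For compound 3 the author estimates 50%, within a range from 25% to 75%.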

Compound 3, a percentage reported as inhibition, at one concentration (the size of the read-out at that concentration, not a potency): 79.6%
For compound 3 the middle estimate is 29.6 percentage points below the measured one; measured number outside the range, above it.
By their numbers in this assay, from the lowest: compound 2; then compound 1; then compound 3.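

In this assay, nitro in place of hydrogen on an aromatic carbon, para to a large group, gives a number 31 percentage points higher from compound 1 to compound 3 (beyond the scatter). Among these compounds, this is the first step between measured compounds that differ in one place, and it shows that what this carbon carries matters: the change from phenyl to 4-nitrophenyl alone moves the read-out beyond the scatter. Nothing in the data offers an explanation for the size of this step.

As far as these compounds go, whether the rise belongs to nitro itself or would also come with another group on this carbon, such as an amine, a nitrile or a carboxylic acid, stays open. So does whether nitro on another carbon of this ring, or on one of the other phenyl groups of compound 1, would give a step of similar size.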